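Ester in Place of Pentyl: Expectation for Compound 4

The source may hold more compounds than are shown below. What is called first, only, known or untested is meant among the compounds shown, and "the series" means these compounds.

Three compounds of the series have numbers in an assay on FRT-Jurkat cells for inhibition of nuclear factor NF-kappa-B complex (Homo sapiens), read by flow cytometry, with a stated time of 24 h, tested at 10 uM; a higher number here means more inhibition at the concentration tested (going by the name of the read-out), a lower number less inhibition. Compound 1 `CCCCCc1ccc(Nc2ccc3c(c2)C(=O)N(C2CCC(=O)NC2=O)C3=O)cc1` gives 12%. Compound 2 `CCCCCc1ccc(Nc2cccc3c2C(=O)N(C2CCC(=O)NC2=O)C3=O)cc1` has its core joined to the aniline differently from that of compound 1; compound 2 gives 23%, and compound 3 `CC(=O)c1ccc(Nc2cccc3c2C(=O)N(C2CCC(=O)NC2=O)C3=O)cc1` gives 2%. Compound 1 therefore stands second highest of the three: compound 3 is its nearest neighbour, with a number within the scatter of it, while compound 2 is furthest, with a number beyond the scatter above it.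

Going by the values given here, only one step between compounds differing in a single place has been measured, a number 21 percentage points lower from compound 2 to compound 3 (beyond the scatter), a modest fall in inhibition when acetyl replaces pentyl on an aromatic carbon. Compound 4 `CCOC(=O)c1ccc(Nc2ccc3c(c2)C(=O)N(C2CCC(=O)NC2=O)C3=O)cc1` differs from compound 1 by ethoxycarbonyl in place of pentyl on an aromatic carbon. This change is of the same kind as the measured one, pentyl leaving and a carbonyl-bearing group entering on the aromatic ring, though on the core of compound 1 rather than that of compound 2. The step from compound 2 to compound 3 bears directly on it, and a fall of comparable size is expected, limited by the already low number of compound 1, which cannot fall much further in this assay. The expected step is a number 9 percentage points lower from compound 1 to compound 4 (within the scatter). For compound 4 the estimate is 3%, in the range -8% to 14%.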

Compound 4, a percentage reported as inhibition, at one concentration (the size of the read-out at that concentration, not a potency): 5%
The estimate for compound 4 lay 2 percentage points below the measured number; the measured number falls inside the stated range.
By their numbers in this assay, from the lowest: compounds 3, 4 and 1 (each within the scatter of the next); then compound 2.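

On the core of compound 1, the para position holds its first single change in this assay: a number 7 percentage points lower from compound 1 to compound 4 (within the scatter). Pentyl and ethoxycarbonyl, each with the same count of heavy atoms but differing in hydrogen-bond acceptors, are therefore not told apart here, whereas acetyl in place of pentyl on the core of compound 2 gave a step beyond the scatter, a number 21 percentage points lower from compound 2 to compound 3 (beyond the scatter). The two steps involve different entering groups on different cores, so the pair does not establish whether the core, the entering group or the low starting number of compound 1 sets the difference in outcome, and no measurement given here offers an explanation for the result.

Still open, on these data alone, is whether any group at this place on the core of compound 1 can lift the number clear of the scatter around compound 1, for instance an amine, a carboxylic acid or a chain longer than pentyl. Also open, as far as these compounds go, is how ethoxycarbonyl reads on the core of compound 2, the pairing that would separate the effect of the entering group from that of the core.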